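The source may report more compounds than this note shows. Statements on the series, on what has been measured and on what is new or still open speak of the compounds shown alone.

Working notes on the series.

Of the compounds shown here, two carry the same core and have been measured. Compound 1 `CCN1CCN(CC(=O)Nc2nc3ccccc3[nH]2)CC1` gives in a functional assay, read by spectrophotometry, with a stated time of 30 min, tested at 25 ug/mL (on this read-out lower numbers stand for a weaker effect and higher numbers for a stronger effect at the one concentration tested), a value of 26.6%. Compound 2 `O=C(CN1CCN(c2ncccn2)CC1)Nc1nc2ccccc2[nH]1` gives in this assay a value of 20.4%. Going by the values given here, the only step between measured compounds, a number 6.2 percentage points lower from compound 1 to compound 2 (within the scatter), lies within the scatter, so the two numbers cannot be told apart. On the numbers as they stand, compound 2 is at the lower end of the pair, with compound 1 as its nearest neighbour, and the gap between them is within the scatter.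

Compound 3 `COc1ccc(N2CCN(CC(=O)Nc3nc4ccccc4[nH]3)CC2)cc1` has not been measured. It differs from compound 2 by 4-methoxyphenyl in place of pyrimidin-2-yl on an amine nitrogen in a ring. Among the compounds with values here, the one measured step bearing on this change is the exchange at the same ring nitrogen from compound 1 to compound 2, which was within the scatter. Nothing in the measured numbers points to a step beyond the scatter in this assay in either direction. Compound 3 is therefore expected to give about 22%, in the range 10% to 38%. The expected step is a number 1.6 percentage points higher from compound 2 to compound 3 (within the scatter), which is not expected to exceed the scatter.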

Compound 3, a percentage reported as activity, at one concentration (the size of the read-out at that concentration, not a potency): 13.3%
Compound 3: the middle estimate sits 8.7 percentage points above what was measured; measured number inside the range.
By their numbers in this assay, from the lowest: compounds 3, 2 and 1 (each within the scatter of the next, the first and the last beyond it).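

At the amine nitrogen in the ring, this assay now shows a step beyond the scatter, though a modest one: a number 13.3 percentage points lower from compound 1 to compound 3 (beyond the scatter) with 4-methoxyphenyl in place of ethyl. The exchange between the two aromatic groups, a number 7.1 percentage points lower from compound 2 to compound 3 (within the scatter) as 4-methoxyphenyl replaces pyrimidin-2-yl, stays within the scatter, so the position is sensitive to its group, but only the ethyl and 4-methoxyphenyl compounds can be separated, and compound 2 cannot be told apart from either and stands against any simple split between ethyl and aromatic groups. Nothing at hand accounts for the size or direction of the step.

An unsubstituted phenyl group on the same ring nitrogen would show whether the methoxy group contributes to the gap from compound 1 to compound 3, while a hydrogen or a longer alkyl chain such as butyl would show how the read-out follows the group on the alkyl side. All of these readings rest on a single concentration, so they describe only a stronger or weaker effect at that concentration.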